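The source may hold more compounds than are shown below. What is called first, only, known or untested is meant among the compounds shown, and "the series" means these compounds.

In a functional assay on A549 cells (Homo sapiens) for inhibition, read by MTT assay, with a stated time of 48 h (on this read-out higher numbers stand for weaker inhibition and lower numbers for stronger inhibition), compound 1 `O=[N+]([O-])c1ccc(C(c2c[nH]c3ccc(Br)cc23)c2c[nH]c3ccc(Br)cc23)cc1` gives 5500 nM. Compound 2 `CCCCCCCC(c1c[nH]c2ccc(Br)cc12)c1c[nH]c2ccc(Br)cc12` carries the change (heptyl in place of 4-nitrophenyl on a saturated chain carbon bound to two aromatic carbons), and in this assay compound 2 gives 3500 nM. The measured size of this change is a 1.6-fold lower number from compound 1 to compound 2 (0.20 log units; within the scatter). Compound 3 `O=[N+]([O-])c1ccc(C(c2c[nH]c3ccc([N+](=O)[O-])cc23)c2c[nH]c3ccc([N+](=O)[O-])cc23)cc1` has a core that differs from the core of compound 1, and the difference between the two cores is not broken down here. In this assay compound 3 gives > 100000 nM, which is a limit of the assay and not a number, as shown by the limit of > 100000 nM in this assay, at which 1 of the 3 values shown sits. Compound 4 `CCCCCCCC(c1c[nH]c2ccc([N+](=O)[O-])cc12)c1c[nH]c2ccc([N+](=O)[O-])cc12` is not yet measured and differs from compound 3 by heptyl in place of 4-nitrophenyl on a saturated chain carbon bound to two aromatic carbons, the same change as in the earlier pair, at the same place. The step from compound 3 to compound 4 is expected to be of similar small size, a step that the limit leaves unreadable from compound 3 to compound 4, and this expectation rests on the earlier step of a 1.6-fold lower number from compound 1 to compound 2 (0.20 log units; within the scatter). Compound 4 is therefore expected in this assay to give 150000 nM, somewhere between 50000 nM and 500000 nM, with a strong chance that again only a limit is reported.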

Compound 4, half-maximal inhibitory concentration: 12500 nM
Compound 4: middle estimate off by 12-fold (1.08 log units), on the high side, outside the stated range (below it).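

In this assay, putting heptyl in place of 4-nitrophenyl on a saturated chain carbon bound to two aromatic carbons gives an at least 8.0-fold lower number from compound 3 to compound 4 (0.90 log units; beyond the scatter), so this change does not carry over at one size from the core of compound 1 to the core of compound 3: the same change on two cores in this assay, a 1.6-fold lower number (0.20 log units; within the scatter) from compound 1 to compound 2 and an at least 8.0-fold lower number (0.90 log units; beyond the scatter) from compound 3 to compound 4, at least 5.0-fold (0.70 log units) apart, beyond the scatter of two such steps. Compound 3 gives > 100000 nM, which is a limit of the assay and not a number, so the step from it fixes only the smallest size the change can have on this core: the limit of > 100000 nM in this assay, at which 1 of the 4 values shown sits. Going by these compounds alone, with only two pairs, this shows that the size of the change depends on the core here, but it neither explains the gap nor predicts the step on any further core.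

The compounds shown leave open whether a longer chain in place of heptyl would also give steps that differ between the two cores. They also leave open how an amine in place of the nitro groups on the core of compound 4 would read in this assay.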